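The compounds below may be only part of what the source reports. "The series", "measured", "known", "first", "only" and "open" are said of these compounds alone.

Measured in a functional assay on MDA-MB-231 cells (Homo sapiens) for antiproliferative activity, read by MTT assay, with a stated time of 72 h; a higher number here means a weaker inhibitor, a lower number a stronger inhibitor:
- Compound 1 `CC1=CCC2C(CC[C@@]2(C)O)C(C)(C)C1CC[C@@H]1[C@@]2(C)CC[C@@H](O)C(C)(C)O[C@@H]2CC[C@]1(C)O`: > 50000 nM (a limit of the assay, not a number)
- Compound 2 `CC1=CC[C@H]2[C@H](CC[C@]2(C)O)C(C)(C)[C@@H]1CC[C@H]1[C@]2(C)CC[C@H](OC(=O)c3ccncc3)C(C)(C)O[C@H]2CC[C@@]1(C)O`: 18000 nM
- Compound 3 `CC1=CC[C@H]2[C@@H]1CC=C(C)[C@@H](CC[C@H]1[C@]3(C)CC[C@H](OC(=O)c4ccncc4)C(C)(C)O[C@H]3CC[C@@]1(C)O)C2(C)C`: 19100 nM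

Compound 2 and compound 3 lie within the scatter of each other, so neither can be ranked over the other. Going by the values given here, the only other reading in this assay is the limit for compound 1, which leaves just these two numbers to work from.

The next compound is compound 4 `CC1=CC[C@H]2[C@H](CC[C@]2(C)O)C(C)(C)[C@@H]1CC[C@H]1[C@]2(C)CC[C@H](OCc3ccccc3)C(C)(C)O[C@H]2CC[C@@]1(C)O`, which keeps the shared core of compound 2 and changes in one place: benzyl in place of (pyridin-4-yl)carbonyl on an oxygen on a saturated carbon. Benzyl takes the place of (pyridin-4-yl)carbonyl on an oxygen on a saturated carbon, so the six-membered aromatic ring remains but is now of carbon only.

Among the compounds with values here, no measured pair covers this change, so the expectation is anchored on compound 2 at 18000 nM, with a wide margin. The expected step of a 1.1-fold higher number from compound 2 to compound 4 (0.05 log units; within the scatter) is small, stays within the scatter, and has no firm direction. For compound 4 the estimated value is 20000 nM, with an expected range of 8000 nM to 45000 nM.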

Compound 4, half-maximal inhibitory concentration: 29100 nM
Compound 4: the middle estimate sits 1.5-fold (0.16 log units) below what was measured; the range from low to high includes it.
By their numbers in this assay, from the lowest: compounds 2, 3 and 4 (each within the scatter of the next). At a limit, above all of these: compound 1.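

In this assay, going by these compounds alone, the change on an oxygen on a saturated carbon gives a 1.6-fold higher number from compound 2 to compound 4 (0.21 log units; within the scatter); this is the first step read at this place. Benzyl brings no ring nitrogen, no carbonyl and no hydrogen-bond acceptors, yet the reading does not leave the scatter, so in this pair neither the ring nitrogen nor the carbonyl of (pyridin-4-yl)carbonyl is required for a value in this range. The compounds shown offer no measured reason for this outcome.

Still open, on these data alone, is whether any group on this oxygen can move the reading beyond the scatter, for instance a chain ending in an amine or a carboxylic acid. Also open, as far as these compounds go, is whether a longer chain between the oxygen and the aromatic ring would change the value.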